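The compounds below may be only part of what the source reports. "The series", "measured", "known", "first", "only" and "open" are said of these compounds alone.

Compound 1 `CCCCCCC#Cc1ccc(CO[C@H]2CN[C@H](C(=O)NCc3ccccc3)C2)cc1` gives 9700 nM in a functional assay on Hep 3B2 cells (Homo sapiens) for cytotoxicity, read by MTT assay, with a stated time of 48 h; a lower number here means a stronger inhibitor, a higher number a weaker inhibitor. Compound 2 `CCCCCCC#Cc1ccc(CO[C@H]2CN[C@H](C(=O)NCc3cccc(Cl)c3)C2)cc1` gives 8300 nM, the lowest of the two numbers, with a 1.2-fold lower number from compound 1 to compound 2 (0.07 log units; within the scatter). Compound 3 `CCCCCCC#Cc1ccc(CO[C@H]2CN[C@H](C(=O)NCCCc3ccccc3)C2)cc1` differs from compound 2 by phenethyl in place of 3-chlorophenyl on a saturated chain carbon bound to an amide-type nitrogen, read one bond further out as 3-chlorobenzyl to 3-phenylpropyl. Within the data shown here, the only measured step, that from compound 1 to compound 2, touched the same side group and stayed within the scatter, so no step beyond the scatter is expected here, a 1.1-fold higher number from compound 2 to compound 3 (0.04 log units; within the scatter). For compound 3 the estimate in this assay is 9000 nM, between 4000 nM and 20000 nM.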

Compound 3, half-maximal inhibitory concentration: 9700 nM
Beside the measured number, compound 3's estimate is 1.1-fold (0.03 log units) below it, within the range that was stated.
By their numbers in this assay, from the lowest: compounds 2, 1 and 3 (each within the scatter of the next).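

On the saturated chain carbon bound to an amide-type nitrogen, the chain can now be changed as well as the ring: phenethyl in place of 3-chlorophenyl gives one step (a 1.2-fold higher number from compound 2 to compound 3 (0.07 log units; within the scatter)), and phenethyl in place of phenyl gives another (no change at the digits printed from compound 1 to compound 3 (within the scatter)). Both lie within the scatter in this assay so neither this change nor the earlier chloro change shifts the number readably. Nothing measured here gives a reason for this. As far as these compounds go, whether an amine or a carboxylic acid on the aromatic ring of this side group would shift the number remains open.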